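The source may report more compounds than this note shows. Statements on the series, on what has been measured and on what is new or still open speak of the compounds shown alone.

Measured compounds:
- compound 1 `Fc1ccc(-c2cc3c(cn2)ncn3-c2ccc(OC(F)F)cc2)c(Cl)c1`: 90 nM
- compound 2 `Cc1cc(F)c(F)cc1-c1cc2c(cn1)ncn2-c1ccc(OC(F)F)cc1`: 220 nM

In a functional assay on HL-60 cells (Homo sapiens) for activation, read by flow cytometry, with a stated time of 4 days (on this read-out lower numbers stand for an effect already at smaller amounts and higher numbers for an effect only at larger amounts of compound), compound 1 gives 90 nM. Going by the values given here, compound 2, in which 4,5-difluoro-2-methylphenyl replaces 2-chloro-4-fluorophenyl on an aromatic carbon, gives 220 nM in this assay, which is the higher of the two numbers known; the step of a 2.4-fold higher number from compound 1 to compound 2 (0.39 log units; beyond the scatter) is modest but beyond the scatter. Among the compounds with values here, compound 2 thus stands at the high end of the two values measured so far.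

Compound 3 `Cc1cc(F)ncc1-c1cc2c(cn1)ncn2-c1ccc(OC(F)F)cc1` is not yet measured. It differs from compound 2 by a group of 8 heavy atoms (6 carbon, 1 nitrogen, 1 fluorine; one six-membered aromatic ring with 1 hetero atom) in place of a group of 9 heavy atoms (7 carbon, 2 fluorine; one six-membered aromatic ring of carbon only), on an aromatic carbon. Within the data shown here, only one measured step exists, the one from compound 1 to compound 2, and it exchanges one carbon-only ring for another; no measured pair changes a ring carbon for a ring nitrogen in this part of the molecule. Among the measured compounds shown here, the expectation for compound 3 can therefore rest only on the position of compound 2 and on the small size of the one step seen. A step of a 1.4-fold higher number from compound 2 to compound 3 (0.13 log units; within the scatter) in this assay is expected, with wide uncertainty in either direction. Compound 3 is estimated at 300 nM, in a range of 80 nM to 1200 nM.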

Compound 3, half-maximal effective concentration: 1200 nM
Estimate against measurement, compound 3: 4.0-fold (0.60 log units) below; the measured number falls inside the stated range.
By their numbers in this assay, from the lowest: compound 1; then compound 2; then compound 3.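

In this assay, the new result shows that this aromatic carbon of the core is more sensitive to the choice of group than the two carbon-only rings had suggested: replacing the 4,5-difluoro-2-methylphenyl with the ring holding one hetero atom gives a 5.5-fold higher number from compound 2 to compound 3 (0.74 log units; beyond the scatter), a wider step than the one between those two carbon-only rings. Set against the 2-chloro-4-fluorophenyl, the same ring gives a 13-fold higher number from compound 1 to compound 3 (1.12 log units; beyond the scatter), the only large step in the series, so compound 3 has the highest number of the three, and its steps to both others lie beyond the scatter. No measurement here bears on why this ring behaves differently from the other two.

The entering group differs from the 4,5-difluoro-2-methylphenyl in more than its ring nitrogen, since it also carries one fluorine rather than two, so the compounds shown do not separate the contribution of the nitrogen from that of the fluorine count. They also leave open how this position would respond to a plain phenyl or to a ring carrying an amine or a carboxylic acid.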